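Changing the aryl on the carbon double-bonded to nitrogen

The source may hold more compounds than are shown below. What is called first, only, known or untested is meant among the compounds shown, and "the series" means these compounds.

Of the compounds shown here, three sharing one core have been tested in a functional assay on U-87MG ATCC cells (Homo sapiens) for cytotoxicity, read by MTT assay, with a stated time of 72 h; a lower number here means a stronger inhibitor, a higher number a weaker inhibitor. Compound 1 `CN(C)CCn1cnnc1-c1cc(Oc2ccc(NC(=O)N/N=C/c3c(Cl)cccc3Cl)cc2F)ccn1` gives only an assay limit, > 100000 nM. Compound 2 `COc1ccc(/C=N/NC(=O)Nc2ccc(Oc3ccnc(-c4nncn4CCN(C)C)c3)c(F)c2)c(OC)c1` gives 12600 nM, and compound 3 `CN(C)CCn1cnnc1-c1cc(Oc2ccc(NC(=O)N/N=C/c3cccc(Br)c3)cc2F)ccn1` gives 830 nM, the lowest of the measured numbers. The steps of an at least 120-fold lower number from compound 1 to compound 3 (2.08 log units; beyond the scatter) and a 15-fold lower number from compound 2 to compound 3 (1.18 log units; beyond the scatter) show that the aryl group on the carbon with a double bond to nitrogen moves the result strongly. Compound 4 `CN(C)CCn1cnnc1-c1cc(Oc2ccc(NC(=O)N/N=C/c3cc(Br)c(O)c(Br)c3)cc2F)ccn1` carries 3,5-dibromo-4-hydroxyphenyl in place of 3-bromophenyl on a carbon with a double bond to nitrogen. Among the compounds with values here, no measured step adds a hydroxyl at this place, so only the size of the earlier aryl swaps serves as a guide. A modest shift toward a higher number is expected, by a 1.8-fold higher number from compound 3 to compound 4 (0.26 log units; within the scatter). Compound 4 is therefore estimated at 1500 nM, between 300 nM and 8000 nM.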

Compound 4, half-maximal inhibitory concentration: > 100000 nM
Compound 4 was reported as a limit; the forecaster's own chance of this, stated with the estimate: 5%; at least 66-fold (1.82 log units) between middle value and limit.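

Swapping in 3,5-dibromo-4-hydroxyphenyl gives an at least 120-fold higher number from compound 3 to compound 4 (2.08 log units; beyond the scatter) and an at least 7.9-fold higher number from compound 2 to compound 4 (0.89 log units; beyond the scatter), so carrying bromine does not by itself keep the number low at this place. Compound 4 is reported only as a limit, and so is compound 1: the limit of > 100000 nM in this assay, at which 2 of the 4 values shown sit. Since both values are limits, the step between those two compounds cannot be read.

The compounds shown do not separate the effect of the hydroxyl from that of the second bromine. A phenyl carrying only the hydroxyl, or one carrying only the two bromines, would pull them apart.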